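The compounds below may be only part of what the source reports. "The series", "measured", "known", "first", "only" and "open" are said of these compounds alone.

Values in a functional assay on NCI-H1581 cells (Homo sapiens) for inhibition, read by MTT assay, with a stated time of 48 h, tested at 10 uM (on this read-out higher numbers stand for more inhibition at the one concentration tested (going by the name of the read-out) and lower numbers for less inhibition), for the measured members of the series:

compound 1 `CCc1ccc(Nc2cc(NC(=O)Nc3cc(OC)cc(OC)c3)ncn2)cc1`: 32.7%
compound 2 `COc1cc(NC(=O)Nc2cc(Nc3ccc(C)c(C)c3)ncn2)cc(OC)c1`: 20.1%
compound 3 `COc1cc(NC(=O)Nc2cc(Nc3cc(F)ccc3OC)ncn2)cc(OC)c1`: 42.1%

Compound 3 holds the highest of the three numbers. Its nearest neighbour is compound 1, and the gap a number 9.4 percentage points higher from compound 1 to compound 3 (within the scatter) lies within the scatter, so the two are not ordered. Compound 2 stands furthest off, with the step of a number 22 percentage points higher from compound 2 to compound 3 (beyond the scatter) beyond the scatter; the step of a number 12.6 percentage points lower from compound 1 to compound 2 (beyond the scatter) is also beyond it.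

Compound 4 `COc1cc(NC(=O)Nc2cc(Nc3cc(C(F)(F)F)ccc3OC)ncn2)cc(OC)c1` is the next member. It differs from compound 3 in one place: trifluoromethyl in place of fluoro on an aromatic carbon. All three measured steps exchange the whole aryl group on the nitrogen of the shared core, and none alters a single substituent on the ring of compound 3 while the methoxy group stays. For the measured compounds named here, the measured steps therefore do not bear directly on this change; they show only that rearranging that aryl group moves this assay by modest amounts, the largest being a number 22 percentage points higher from compound 2 to compound 3 (beyond the scatter).

Going by the values given here, with no closer precedent, the step of a number 2.9 percentage points higher from compound 3 to compound 4 (within the scatter) is expected to stay within the scatter. Compound 4 is estimated at 45%, in the range 28% to 62%.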

Compound 4, a percentage reported as inhibition, at one concentration (the size of the read-out at that concentration, not a potency): 67.1%
The estimate for compound 4 lay 22.1 percentage points below the measured number; measured number above the stated range.
By their numbers in this assay, from the lowest: compound 2; then compounds 1 and 3 (each within the scatter of the next); then compound 4.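

For the compounds shown here, the exchange at this aromatic carbon, para to a methoxy group and meta to a large group, gives a number 25 percentage points higher from compound 3 to compound 4 (beyond the scatter) in this assay, and it is the first step that changes one substituent while the methoxy group stays. A single substituent at this position therefore moves the read-out by about as much as the exchange of the whole aryl group in a number 22 percentage points higher from compound 2 to compound 3 (beyond the scatter). Nothing available accounts for the size of this step.

Open, on these data alone, is whether a methyl group, a chlorine atom or a nitrile on this carbon would give a number close to that of compound 3 or that of compound 4. Also open, as far as these compounds go, is whether the step persists when the methoxy group gives way to an ethoxy group or a hydrogen.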